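Removing an Amino Group from a Sulfonyl Aryl Ring

A few compounds are considered here, and "the series" means these few. Any claim that something is new, unique, unknown or untested is made for them only; others in the source may bear on it.

Three compounds have been measured in a functional assay on DU-145 cells (Homo sapiens) for inhibition, read by trypan blue exclusion, with a stated time of 72 h; on this read-out lower numbers stand for stronger inhibition and higher numbers for weaker inhibition:
Compound 1, `Cn1c(=O)c(C(=O)Nc2ccc(F)cc2)cc2cnc(Nc3ccc4[nH]ccc4c3)nc21`, gives 5000 nM.
Compound 2, `Cn1c(=O)c(C(=O)Nc2ccc(F)cc2F)cc2cnc(Nc3ccc4[nH]ccc4c3)nc21`, gives 5000 nM.
Compound 3, `Cn1c(=O)c(S(=O)(=O)c2ccc(N)cc2F)cc2cnc(Nc3ccc4[nH]ccc4c3)nc21`, gives 8000 nM.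

Compound 3 shows the highest of the three numbers, yet the two steps that lead to it, a 1.6-fold higher number from compound 1 to compound 3 (0.20 log units; within the scatter) and a 1.6-fold higher number from compound 2 to compound 3 (0.20 log units; within the scatter), both lie within the scatter, so the three compounds cannot be told apart on these numbers. Compound 4, `Cn1c(=O)c(S(=O)(=O)c2ccc(F)cc2)cc2cnc(Nc3ccc4[nH]ccc4c3)nc21`, keeps the shared core and the sulfonyl link of compound 3 and differs only in the aryl group on the sulfonyl sulfur: 4-fluorophenyl in place of 4-amino-2-fluorophenyl on a sulfonyl sulfur.

For the measured compounds named here, no measured step removes an amino group from an aryl ring. The nearest comparison is no change at the digits printed from compound 1 to compound 2 (within the scatter), where adding a fluorine to an aryl ring left the number unchanged. With nothing pointing in either direction, the step is expected to be no change at the digits printed from compound 3 to compound 4 (within the scatter), none beyond the scatter. Compound 4 is therefore estimated at 8000 nM, with a range from 3000 nM to 20000 nM.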

Compound 4, half-maximal inhibitory concentration: 300 nM
Compound 4: middle estimate off by 27-fold (1.43 log units), on the high side, outside the stated range (below it).
By their numbers in this assay, from the lowest: compound 4; then compounds 1, 2 and 3 (each within the scatter of the next).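

For the compounds shown here, the aryl group on the sulfonyl sulfur turns out to matter a great deal in this assay: 4-fluorophenyl in place of 4-amino-2-fluorophenyl gives a 27-fold lower number from compound 3 to compound 4 (1.43 log units; beyond the scatter) and is the first step here beyond the scatter. The sulfonyl link alone does not set compound 4 apart, since compound 3 carries it too; only (4-fluorophenyl)sulfonyl, in place of the two carbamoyl groups, gives a 17-fold lower number from compound 1 to compound 4 (1.22 log units; beyond the scatter) and a 17-fold lower number from compound 2 to compound 4 (1.22 log units; beyond the scatter) as well. Nothing available here explains why this aryl group stands out.

The step changes the ring at more than one point, so the part played by the amino group cannot be separated from that of the fluorine. Going by these compounds, whether plain phenyl, or a chlorine or methoxy group in place of that fluorine, would hold the number stays open.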